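Swapping the aryl group on the piperazine of a serotonin-7 ligand

A few compounds are considered here, and "the series" means these few. Any claim that something is new, unique, unknown or untested is made for them only; others in the source may bear on it.

Measured so far:
compound 1 `COc1ccc(S(=O)(=O)N(CCCN2CCN(c3ccc(F)cc3)CC2)CC2CCCCC2)cc1`, 980 nM
compound 2 `COc1ccc(S(=O)(=O)N(CCCN2CCN(c3ccccc3OC)CC2)CC2CC2)cc1`, 316 nM

Both compounds were tested in an assay on CHO cells for displacement of a labelled ligand from 5-hydroxytryptamine receptor 7 (Homo sapiens); on this read-out higher numbers stand for weaker inhibition and lower numbers for stronger inhibition. Compound 2 gives 316 nM, the lower of the two numbers, and compound 1 gives 980 nM, a gap that lies beyond the usual scatter. These two compounds differ in two places at once, so no single step can be read from them.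

Compound 3 `COc1ccc(S(=O)(=O)N(CCCN2CCN(c3ccc(F)cc3)CC2)CC2CC2)cc1` has not yet been measured. It differs from compound 2 in one place: 4-fluorophenyl in place of 2-methoxyphenyl on an amine nitrogen in a ring. In the rest of the molecule compound 3 matches compound 2.

Compound 1 also carries the 4-fluorophenyl group on the ring nitrogen and gives 980 nM in this assay, the higher number of the two. The expected step in this assay from compound 2 to compound 3 is therefore a rise, a 2.4-fold higher number from compound 2 to compound 3 (0.38 log units; beyond the scatter), beyond the scatter. The estimate for compound 3 in this assay is 750 nM, with a range from 250 nM to 2200 nM.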

Compound 3, half-maximal inhibitory concentration: 93 nM
Beside the measured number, compound 3's estimate is 8.1-fold (0.91 log units) above it; the measured number lies below the stated range.
By their numbers in this assay, from the lowest: compound 3; then compound 2; then compound 1.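

Among the compounds shown here, with the cyclopropyl group held fixed in this assay, the aryl group on the amine nitrogen in the ring can be read on its own for the first time: 4-fluorophenyl in place of 2-methoxyphenyl gives a 3.4-fold lower number from compound 2 to compound 3 (0.53 log units; beyond the scatter) and so strengthens inhibition, a modest step beyond the scatter. The weak inhibition of compound 1 therefore cannot be pinned on its 4-fluorophenyl group, since cyclopropyl in place of cyclohexyl on the saturated chain carbon bound to the sulfonamide nitrogen gives an 11-fold lower number from compound 1 to compound 3 (1.02 log units; beyond the scatter) with that group unchanged, a large step that makes compound 3 the strongest of the three. No measurement shown here explains why either change moves the number.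

On these data alone, both steps run through compound 3 alone, so it remains open whether the aryl change would give a similar step with the cyclohexyl group in place. Also open, as far as these compounds go, is how the number would respond to a plain phenyl group on the ring nitrogen, or to a cyclobutyl or cyclopentyl group or an open propyl chain in place of the cyclopropyl group.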